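Pyrrolyl Substituent on the Chromene Core, Expected Aortic Activity

The source may hold more compounds than are shown below. What is called first, only, known or untested is meant among the compounds shown, and "the series" means these compounds.

Of the compounds shown here, three have been measured in a functional assay (aorta) with Rattus norvegicus as the target; a lower number here means a less potent compound, a higher number a more potent compound, by a factor of ten per unit of this negative logarithm. Compound 1 `CC1(C)C=C(n2ccccc2=O)c2cc(C(=O)c3ccccc3F)ccc2O1` gives 7.08; compound 2 `CC1(C)C=C(n2ccccc2=O)c2cc(C(=N)NO)ccc2O1` gives 5.99; compound 3 `CC1(C)C=C(n2ccccc2=O)c2cc(C=O)ccc2O1` gives 6.91. Compound 3 stands second highest of the three numbers; its nearest neighbour is compound 1, with a number 0.17 log units lower from compound 1 to compound 3 (within the scatter), and its furthest is compound 2, with a number 0.92 log units higher from compound 2 to compound 3 (beyond the scatter).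

Compound 4 `Cc1ccc(C)n1-c1ccc2c(c1)C(n1ccccc1=O)=CC(C)(C)O2` is the next candidate. Relative to compound 3 the change is 2,5-dimethyl-1H-pyrrol-1-yl in place of formyl on an aromatic carbon.

For the measured compounds named here, two measured steps bear on this change. The step from a 2-fluorophenyl ketone to a formyl group, a number 0.17 log units lower from compound 1 to compound 3 (within the scatter), shows that exchanging a large aromatic group for a small one at this aromatic carbon leaves the number essentially where it was. The step of a number 0.92 log units higher from compound 2 to compound 3 (beyond the scatter), by contrast, shows that the amidoxime is clearly the weakest of the three substituents tried at this carbon. Compound 4 brings in another aromatic group, so the expectation rests on compound 1 and compound 3 rather than on compound 2. A step of about a number 0.04 log units higher from compound 3 to compound 4 (within the scatter) is therefore expected, within the usual scatter. The estimate for compound 4 in this assay is 6.95, with a range from 6.25 to 7.65.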

Compound 4, logarithm of the reciprocal of the active concentration, log(1/C): 7.27
Estimate against measurement, compound 4: 0.32 log units below; measured number inside the range.
By their numbers in this assay, from the lowest: compound 2; then compounds 3, 1 and 4 (each within the scatter of the next, the first and the last beyond it).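

In this assay, the 2,5-dimethyl-1H-pyrrol-1-yl group is the only substituent at this aromatic carbon that stands clear of formyl on the upper side, with a number 0.36 log units higher from compound 3 to compound 4 (beyond the scatter). Against the (2-fluorophenyl)carbonyl group it gives a number 0.19 log units higher from compound 1 to compound 4 (within the scatter), so a carbonyl attached to this carbon, present in compound 1 and compound 3, is not needed for a number of this size, since the entering group in compound 4 has none. The amidoxime remains well apart, with a number 1.28 log units higher from compound 2 to compound 4 (beyond the scatter), the widest gap in the set, and no measurement shown accounts for any of these steps.

The compounds shown leave open what the two methyl groups on the pyrrole contribute, and the unsubstituted 1H-pyrrol-1-yl group or a phenyl ring bonded directly to this carbon would separate the effect of those methyl groups from that of the aromatic ring. It also remains open how far the number moves with an amine or a carboxylic acid at this carbon, as the substituents shown are limited to formyl, the amidoxime, the aryl ketone and the pyrrole.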